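This account rests on a few compounds, and the source may have more. Where it says the series, first, only, none or still open, it means among the compounds named here.

Within the data shown here, in an ADME assay on liver for metabolic stability, with Liver microsome (Homo sapiens) as the target, using microsomes, with a stated time of 10 min, tested at 0.5 uM (on this read-out higher numbers stand for a more stable compound and lower numbers for a less stable compound), compound 2 `Cc1ccncc1-c1cccc2c1cnn2-c1ccccc1` gives 78%, the lowest of the three numbers so far. Compound 1 `Cc1ccncc1-c1cccc2c1cnn2-c1cccnn1` gives 89% and compound 3 `Cc1ccncc1-c1cccc2c1ncn2-c1cscn1` gives 90%, both beyond the scatter from compound 2. Compound 4 `Cc1ccncc1-c1cccc2c1cnn2-c1ccccn1` has not yet been measured, and it differs from compound 2 in one place: pyridin-2-yl in place of phenyl on an aromatic nitrogen. Among the measured compounds shown here, one measured step bears on this change, since it involves the same phenyl at the same place: a number 11 percentage points lower from compound 1 to compound 2 (beyond the scatter). That modest step suggests that replacing phenyl with pyridin-2-yl may give a rise of similar size in this assay. The expected step is a number 11 percentage points higher from compound 2 to compound 4 (beyond the scatter). Compound 4 is estimated at 89%, with an expected range of 79% to 97%.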

Compound 4, percent of the compound remaining: 95%
Compound 4: the middle estimate sits 6 percentage points below what was measured, within the range that was stated.
By their numbers in this assay, from the lowest: compound 2; then compounds 1, 3 and 4 (each within the scatter of the next).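

In this assay, a second ring with nitrogen in it, pyridin-2-yl, now stands above phenyl on this aromatic nitrogen, with a number 17 percentage points higher from compound 2 to compound 4 (beyond the scatter), so the gain seen with pyridazin-3-yl is not a single case. The two nitrogen-containing rings cannot be told apart, with a number 6 percentage points higher from compound 1 to compound 4 (within the scatter) lying within the scatter. Nothing here shows why these rings differ from phenyl. Going by these compounds, whether a simple amine or a saturated morpholine ring would hold up at this position remains open, as does whether the same change would matter on the core of compound 3.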